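A few compounds are considered here, and "the series" means these few. Any claim that something is new, unique, unknown or untested is made for them only; others in the source may bear on it.

Compound 2 `FC(F)(F)c1ccccc1NC(=S)N/N=C/c1ccc2ccccc2n1` gives 20700 nM in a functional assay on SGC-7901 cells (Homo sapiens) for antiproliferative activity, read by sulforhodamine B assay, with a stated time of 72 h (a lower number here means a stronger inhibitor, a higher number a weaker inhibitor), and of the two numbers available in this assay it is the highest. Compound 3 `CN(C)C(=S)N/N=C/c1ccc2cccnc2n1`, built on a different core and with a dimethyl group in place of the aryl amine, gives 630 nM in this assay, a clearly lower number. Compound 1 `COc1ccccc1NC(=S)N/N=C/c1ccc2ccccc2n1` gives in this assay only a limit, > 100000 nM, which is the upper bound of what the assay can report, as recorded in the limit of > 100000 nM in this assay, at which 1 of the 3 values shown sits.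

For the measured compounds named here, the single measured step between close neighbours is an at least 4.8-fold lower number from compound 1 to compound 2 (0.68 log units; beyond the scatter); it shows that exchanging the group at this position can move the number at least modestly, though it gives no direction for a fluoro group.

Compound 4 `Fc1ccccc1NC(=S)N/N=C/c1ccc2ccccc2n1` differs from compound 2 by fluoro in place of trifluoromethyl on an aromatic carbon. Going by the values given here, with only one step bearing on this position, the expectation is a step of a 1.4-fold higher number from compound 2 to compound 4 (0.16 log units; within the scatter), within the usual scatter. Compound 4 is therefore expected to give about 30000 nM in this assay, with a range from 8000 nM to 100000 nM.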

Compound 4, half-maximal inhibitory concentration: > 100000 nM
Compound 4: a limit, no number; the forecaster's own chance of this, stated with the estimate: 20%; at least 3.3-fold (0.52 log units) between middle value and limit.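

The change from trifluoromethyl to fluoro gives an at least 4.8-fold higher number from compound 2 to compound 4 (0.68 log units; beyond the scatter) and so shows that, among the groups seen here, the number at this position does depend on which group is present. Of the three compounds that differ only at this position, compound 2 alone gives a readable number in this assay, so fluoro joins methoxy in not matching trifluoromethyl. The step from compound 1 to compound 4 cannot be read, and neither compound can be ranked against the other, because both values are limits: the limit of > 100000 nM in this assay, at which 2 of the 4 values shown sit.

From the compounds shown here alone, it remains open whether a chloro, methyl or nitrile group at this position would give a readable number as trifluoromethyl does. Going by these compounds, how an amine or a carboxylic acid would behave there also remains unknown.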